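The source may report more compounds than this note shows. Statements on the series, on what has been measured and on what is new or still open speak of the compounds shown alone.

Compound 1 (`CN(C)c1ncnc2c1c(-c1ccsc1)cn2[C@@H]1O[C@H](CO)[C@@H](O)[C@H]1O`) was examined in a functional assay on CEM-DNR-bulk cells (Homo sapiens), read by MTT assay, with a stated time of 72 h; on this read-out lower numbers stand for stronger inhibition and higher numbers for weaker inhibition. There compound 1 gives > 20000 nM, which is a limit and not a number. Compound 2 (`CN(C)c1ncnc2c1c(-c1cc3ccccc3o1)cn2[C@@H]1O[C@H](CO)[C@@H](O)[C@H]1O`) likewise reaches only a limit, with compound 2 at > 20000 nM. Among the compounds with values here, the one measured change, a step that the two limits leave unreadable from compound 1 to compound 2, puts 1-benzofuran-2-yl in place of thiophen-3-yl and has no readable size. The evidence so far is the limit of > 20000 nM in this assay, at which 2 of the 2 values shown sit.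

Compound 3 (`Cc1ncnc2c1c(-c1ccsc1)cn2[C@@H]1O[C@H](CO)[C@@H](O)[C@H]1O`) keeps the thiophen-3-yl of compound 1 and differs elsewhere: methyl in place of dimethylamino on an aromatic carbon, with methyl in place of dimethylamino on an aromatic carbon, next to the ring nitrogen. Within the data shown here, no measured step touches that place, so the data give no size for this change, and the expectation is a loose one. Since compound 1 stands at > 20000 nM, a limit, any readable result for compound 3 would have to lie toward stronger inhibition, though another limit remains quite possible. For compound 3 the expected step, an estimate only, is an at least 5.0-fold lower number from compound 1 to compound 3 (0.69 log units; beyond the scatter). The estimated value for compound 3 is 4000 nM, with an expected range from 300 nM to 20000 nM.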

Compound 3, half-maximal inhibitory concentration: 8560 nM
Estimate against measurement, compound 3: 2.1-fold (0.33 log units) below, within the range that was stated.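

In this assay, the change at this position gives the first readable value among the compounds shown: methyl in place of dimethylamino, on the aromatic carbon next to the ring nitrogen, gives an at least 2.3-fold lower number from compound 1 to compound 3 (0.36 log units; beyond the scatter). This shows that the place responds to substitution, whereas the earlier swap of thiophen-3-yl for 1-benzofuran-2-yl left nothing that could be read, and compound 3 remains the only one of the compounds shown to escape the assay's limit: the limit of > 20000 nM in this assay, at which 2 of the 3 values shown sit.

As far as these compounds go, compound 1 holds only a limit, so the step gives a minimum size and its full size remains unknown, and it cannot be told whether removing dimethylamino or introducing methyl matters more. From the compounds shown here alone, it also stays open whether an unsubstituted amine, a carboxylic acid or a longer chain such as propyl on this carbon would give a lower or a higher number, and whether methyl would give a readable value alongside 1-benzofuran-2-yl rather than thiophen-3-yl.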